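Compound 3 to compound 4: lengthening the alkenyl chain

The compounds below may be only part of what the source reports. "The series", "measured", "known", "first", "only" and "open" are said of these compounds alone.

- compound 1 `C=C(C)C(=O)Nc1cc2c(N3CCc4ccccc43)ncnc2cc1OC` gives 7320 nM
- compound 2 `C=CC(=O)Nc1cc2c(N3CCc4ccccc43)ncnc2cc1O[C@@H]1CCOC1` gives 9320 nM
- compound 3 `C/C=C/C(=O)Nc1cc2c(N3CCCc4ccccc43)ncnc2cc1OC` gives 8190 nM

All three values come from a functional assay on A549 cells (Homo sapiens) for antiproliferative activity, read by MTT assay, with a stated time of 72 h; on this read-out higher numbers stand for weaker inhibition and lower numbers for stronger inhibition. Compound 3 lies within the scatter of both compound 1 and compound 2, so the three values form a single group and no order can be read among them.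

The next compound is compound 4 `CCC/C=C/C(=O)Nc1cc2c(N3CCCc4ccccc43)ncnc2cc1OC`. Its difference from compound 3 is ethyl in place of hydrogen on a saturated chain carbon bound to a double-bonded chain carbon. In words, this is ethyl in place of hydrogen on a saturated chain carbon bound to a double-bonded chain carbon, which can also be read as prop-1-en-1-yl to pent-1-en-1-yl.

For the measured compounds named here, no two measured compounds differ in one place only, so no measured step bears on this change. Going by the values given here, the only guide is the narrow group of values, with compound 3 at 8190 nM as the starting point. No step beyond the scatter is expected in this assay, in either direction, though this expectation rests on thin evidence. The expected step is a 1.0-fold lower number from compound 3 to compound 4 (0.01 log units; within the scatter). The estimated value for compound 4 is 8000 nM, with an expected range of 3500 nM to 17000 nM.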

Compound 4, half-maximal inhibitory concentration: 1800 nM
For compound 4 the middle estimate is 4.4-fold (0.65 log units) above the measured one, outside the stated range (below it).
By their numbers in this assay, from the lowest: compound 4; then compounds 1, 3 and 2 (each within the scatter of the next).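

Replacing (prop-1-en-1-yl)carbonyl with (pent-1-en-1-yl)carbonyl gives the only step beyond the scatter among these compounds: in this assay, the change produces a 4.6-fold lower number from compound 3 to compound 4 (0.66 log units; beyond the scatter). For the compounds shown here, this places a measured sensitivity at the saturated chain carbon bound to a double-bonded chain carbon, where ethyl in place of hydrogen is tolerated and gives stronger inhibition, something the earlier values could not show with no single-place pair among them. Nothing measured here accounts for the size or direction of this step.

On these data alone, a single pair gives no trend with chain length, so it remains open whether a longer chain such as hept-1-en-1-yl would extend the step, or whether a branched chain, a phenyl group or a terminal dimethylamino group at the same place would preserve it. Also open, as far as these compounds go, is whether pent-1-en-1-yl gives a comparable step on the core of compound 1, and whether the change has the same effect on cell lines other than the one used here.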